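From isopropyl to cyclobutyl: a clearance estimate

The source may hold more compounds than are shown below. What is called first, only, known or untested is meant among the compounds shown, and "the series" means these compounds.

- compound 1 (`COC(=O)N(CCO)c1c(N)nc(-c2nn(Cc3ccccc3F)c3ncccc23)nc1N`) with 61.7 mL/min/kg
- compound 2 (`CC(C)OC(=O)Nc1c(N)nc(-c2nn(Cc3ccccc3F)c3ncccc23)nc1N`) with 15 mL/min/kg

Both numbers come from an ADME assay on cells (Hepatocyte, Rattus norvegicus) for pharmacokinetics, read by LC-MS, with a stated time of 90 min, tested at 1 uM (a higher number here means faster removal of the compound, a lower number slower removal), and are the only ones so far. Compound 2 at 15 mL/min/kg holds the lower of the two.

Compound 3 (`Nc1nc(-c2nn(Cc3ccccc3F)c3ncccc23)nc(N)c1NC(=O)OC1CCC1`) differs from compound 2 in one place, with cyclobutyl in place of isopropyl on an oxygen next to a carbonyl group.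

For the measured compounds named here, the only measured step is a 4.1-fold lower number from compound 1 to compound 2 (0.61 log units; beyond the scatter) and it exchanged a whole (2-hydroxyethyl)(methoxycarbonyl)amino group for (isopropoxycarbonyl)amino. That was a larger exchange than the new one, so its size should not simply be carried over. Going by the values given here, no measured step swaps isopropyl for a ring, so the data offer no direct precedent. The closest guide is therefore compound 2 at 15 mL/min/kg and no step beyond the scatter is expected in this assay in either direction. The estimated change is a 1.2-fold higher number from compound 2 to compound 3 (0.08 log units; within the scatter) and would stay within the scatter. The estimated clearance of compound 3 is 18 mL/min/kg with an expected range from 9 mL/min/kg to 36 mL/min/kg on measurement.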

Compound 3, clearance: 23.3 mL/min/kg
Beside the measured number, compound 3's estimate is 1.3-fold (0.11 log units) below it; low and high end bracket the measured number.
By their numbers in this assay, from the lowest: compounds 2 and 3 (each within the scatter of the next); then compound 1.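

In this assay, placing cyclobutyl instead of isopropyl on the oxygen next to a carbonyl group gives a 1.6-fold higher number from compound 2 to compound 3 (0.19 log units; within the scatter) and so marks no change that can be told apart from repeat-measurement noise. For the compounds shown here, this is the first sign that this position can take a small carbon ring in place of an open, branched group with no readable effect on this measurement. The wider exchange gives a 2.6-fold lower number from compound 1 to compound 3 (0.42 log units; beyond the scatter) and thus places compound 3, like compound 2, clearly apart from compound 1, so the gap from compound 1 holds with either of these two groups on the oxygen. No measurement shown here gives a cause for either step.

Going by these compounds, whether a larger ring such as cyclohexyl, a longer chain such as n-butyl, or a group carrying an amine on this oxygen would also stay close to compound 2 remains open. It is also open whether the 2-hydroxyethyl group or the methoxycarbonyl group of compound 1 matters more, as compound 1 carries both at once and no compound shown separates them.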